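Fluoro for hydrogen on the benzyl ring of compound 3

This account rests on a few compounds, and the source may have more. Where it says the series, first, only, none or still open, it means among the compounds named here.

Measured so far:
compound 1 `O=C(/C=C/c1ccc(OCc2cn(Cc3ccccc3)nn2)cc1)c1ccc(Br)cc1` 34%
compound 2 `O=C(/C=C/c1ccc(OCc2cn(Cc3ccccc3F)nn2)cc1)c1ccc(Br)cc1` 38%
compound 3 `COc1ccc(C(=O)/C=C/c2ccc(OCc3cn(Cc4ccccc4)nn3)cc2)cc1` 70%

In a functional assay on MCF7 cells (Homo sapiens) for inhibition, read by MTT assay, with a stated time of 48 h, tested at 10 uM (a higher number here means more inhibition of growth at the concentration tested, a lower number less inhibition of growth), compound 3 stands highest of the three, beyond the scatter against both others. The step of a number 36 percentage points higher from compound 1 to compound 3 (beyond the scatter) is large; compound 2, the next nearest, sits well below compound 3.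

Compound 4 `COc1ccc(C(=O)/C=C/c2ccc(OCc3cn(Cc4ccc(F)cc4)nn3)cc2)cc1` is not yet measured. It differs from compound 3 by fluoro in place of hydrogen on an aromatic carbon. Among the compounds with values here, the only measured step of the same kind is a number 4 percentage points higher from compound 1 to compound 2 (within the scatter), a change within the scatter that likewise sets fluoro in place of hydrogen on the benzyl ring. Within the data shown here, nothing measured separates the effect of that change on the methoxy series from its effect on the bromo series; the single precedent is what the series offers.

On that precedent the expected step of a number 2 percentage points higher from compound 3 to compound 4 (within the scatter) is small, a shift within the scatter, with no direction that can be stated with confidence. Compound 4 is therefore expected to give about 72% in this assay, with a range from 58% to 84%, close to compound 3 and clearly above compound 1 and compound 2.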

Compound 4, percent growth inhibition at one concentration: 15%
Compound 4: middle estimate off by 57 percentage points, on the high side; the measured number lies below the stated range.
By their numbers in this assay, from the lowest: compound 4; then compounds 1 and 2 (each within the scatter of the next); then compound 3.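

In this assay, the benzyl to 4-fluorobenzyl change on the methoxy-bearing core gives a number 55 percentage points lower from compound 3 to compound 4 (beyond the scatter). Within the data shown here, at this carbon, para to a large group, a single fluoro in place of hydrogen therefore removes most of the growth inhibition seen with compound 3, so this position is far less tolerant of change than the earlier compounds suggested. The effect of fluoro in place of hydrogen on the benzyl ring does not carry over from one pair of compounds to the other: the same change on two cores in this assay, a number 4 percentage points higher (within the scatter) from compound 1 to compound 2 and a number 55 percentage points lower (beyond the scatter) from compound 3 to compound 4, 59 percentage points apart, beyond the scatter of two such steps

The two pairs differ both in the group on the other aromatic ring, bromo or methoxy, and in the benzyl carbon that bears the fluoro, and the compounds shown do not separate these two differences. Also open, from the compounds shown here alone, is whether the drop is specific to fluoro or follows from any substitution at this carbon, a question that chloro, methyl or an amine in the same place on the methoxy-bearing core would address.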